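This account rests on a few compounds, and the source may have more. Where it says the series, first, only, none or still open, it means among the compounds named here.

Measured compounds:
- Compound 1 `COCC1=C(C(=O)NCCCN2CCC(c3ccccc3C#N)CC2)[C@@H](c2ccc(F)c(F)c2)NC(=O)N1`: < 6% (a limit)
- Compound 2 `O=C1NC=C(C(=O)NCCCN2CCC(c3ccc(F)cc3)CC2)[C@@H](c2ccc(F)c(F)c2)N1`: 0%
- Compound 3 `CC1=C(C(=O)NCCCN2CCC(c3ccc(F)cc3)CC2)[C@@H](c2ccc(F)c(F)c2)NC(=O)N1`: < 6% (a limit)

In an in vivo ADME assay on the whole organism (Rattus norvegicus) for pharmacokinetics (a lower number here means that a smaller share of the oral dose reaches the circulation, a higher number that a larger share of the oral dose reaches the circulation), compound 3 gives < 6%. This is a limit of the assay, and compound 3 therefore has no exact position on the scale. The same is true of one other compound, as the limit of < 6% in this assay, at which 2 of the 3 values shown sit, shows.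

Compound 4 `COCC1=C(C(=O)NCCCN2CCC(c3ccc(F)cc3)CC2)[C@@H](c2ccc(F)c(F)c2)NC(=O)N1` has not yet been measured. It differs from compound 3 in one place: methoxy in place of hydrogen on a saturated chain carbon bound to a double-bonded ring carbon. This is methoxy in place of hydrogen on a saturated chain carbon bound to a double-bonded ring carbon, so methyl becomes methoxymethyl.

The only measured step among these compounds is a step that the limit leaves unreadable from compound 2 to compound 3. It is a different change, and it offers no size to carry over. The nearest guide is compound 1, which carries the methoxymethyl group but differs elsewhere. Compound 1 gives < 6%, which is also a limit.

With compound 1 at < 6%, no rise is expected from this change in this assay. The expected result is a step that the limit leaves unreadable from compound 3 to compound 4, which means no step beyond the usual scatter. Compound 4 is estimated at 4%, with an expected range from 0% to 12%.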

Compound 4, oral bioavailability: 26%
Compound 4: middle estimate off by 22 percentage points, on the low side; the whole stated range lies below it.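

In this assay, methyl to methoxymethyl gives a number at least 20 percentage points higher from compound 3 to compound 4 (beyond the scatter), and hydrogen to methoxymethyl on the double-bonded ring carbon gives a number 26 percentage points higher from compound 2 to compound 4 (beyond the scatter), so this position can clearly change the share of the oral dose that reaches the circulation. The methoxymethyl group does not bring this result in every compound shown, since 4-fluorophenyl in place of 2-cyanophenyl on a saturated ring carbon gives a number at least 20 percentage points higher from compound 1 to compound 4 (beyond the scatter) with methoxymethyl present in both compounds. The step from methyl back to hydrogen cannot be read, and the steps that start from a limit give only a smallest size, because two compounds share the same limit: the limit of < 6% in this assay, at which 2 of the 4 values shown sit.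

The compounds shown leave open whether the rise goes with the oxygen of the methoxy group or with the longer chain, a question that a propyl group, with carbon in place of that oxygen, would address. Also open, from the compounds shown here alone, is how a hydroxymethyl or an aminomethyl group would behave at this place, and whether methoxymethyl gives a similar rise alongside other groups on the saturated ring carbon.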